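The compounds below may be only part of what the source reports. "The series", "measured", "known", "first", "only" and "open" are said of these compounds alone.

Compound 2 `Cn1c(-c2ccc([N+](=O)[O-])cc2)nc2cc(C(F)(F)F)ccc21` stands at a limit rather than a number: in an ADME assay on MT4 cells (Homo sapiens) for cytotoxicity, read by MTT assay, with a stated time of 96 h (on this read-out lower numbers stand for higher toxicity in this test and higher numbers for lower toxicity in this test), compound 2 gives >= 100000 nM. The same limit appears for compound 3 `C#C[C@@]1(O)[C@H](O)[C@@H](CO)O[C@H]1n1ccc(N)nc1=O`, which in this assay gives >= 100000 nM. Compound 1 `CCC(=O)Nc1ccc(-c2nc3cc(C(F)(F)F)ccc3n2C2CCCCC2)cc1`, which carries a propionamido group and a cyclohexyl on the core nitrogen, gives 17000 nM in this assay. Two of the three values shown therefore sit at the limit of >= 100000 nM in this assay, at which 2 of the 3 values shown sit. Compound 4 `CC(=O)Nc1ccc(-c2nc3cc(C(F)(F)F)ccc3n2C)cc1` differs from compound 2 by acetamido in place of nitro on an aromatic carbon. Among the measured compounds shown here, with no measured step of this kind to lean on, the change from compound 2 to compound 4 is expected to shift the read-out by an at least 1.6-fold lower number from compound 2 to compound 4 (0.22 log units; that floor lies within the scatter), a movement that may not go beyond the usual scatter. Compound 4 is thus estimated to give about 60000 nM in this assay, within 20000 nM to 100000 nM.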

Compound 4, half-maximal cytotoxic concentration: 15000 nM
Estimate against measurement, compound 4: 4.0-fold (0.60 log units) above; the measured number lies below the stated range.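

Among the compounds shown here, on the aromatic carbon para to a large group, acetamido in place of nitro brings an at least 6.6-fold lower number from compound 2 to compound 4 (0.82 log units; beyond the scatter) in this assay, the first measured step at this position. With acetamido on this carbon, compound 4 gives a number, 15000 nM, rather than a limit. Compound 2 stands at a limit of the assay and not at a number, so the size of this step is only a floor: the limit of >= 100000 nM in this assay, at which 2 of the 4 values shown sit.

On these data alone, whether an amine, a carboxylic acid or a longer acyl chain on this carbon would move the read-out as far remains open. So does whether the same change would hold with the cyclohexyl on the core nitrogen that compound 1 carries.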